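Swapping amino for ethyl on the aryl substituent

The source may hold more compounds than are shown below. What is called first, only, known or untested is meant among the compounds shown, and "the series" means these compounds.

Compound 2 `Nc1ccc(NC2=NCCC3(CCCCC3)S2)cc1` gives 1.88 in a physicochemical assay for lipophilicity, measured as octanol-water partition, at pH 7.4 (a higher number here means a more lipophilic compound, a lower number a more polar compound), the higher of the two numbers measured; compound 1 `CCNC1=NCCC2(CCCCC2)S1` stands at 1.38, a gap beyond the usual scatter. Compound 3 `CCc1ccc(NC2=NCCC3(CCCCC3)S2)cc1` differs from compound 2 by ethyl in place of amino on an aromatic carbon. Among the compounds with values here, no measured pair shows this change, so the direction rests on expectation alone. The expected step of a number 2.02 log units higher from compound 2 to compound 3 (beyond the scatter) is upward and well beyond the scatter. Compound 3 is estimated at 3.9 in this assay, with a range from 3.3 to 4.5.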

Compound 3, distribution coefficient: 2.31
Compound 3: the middle estimate sits 1.59 log units above what was measured, and the stated range ends above it.
By their numbers in this assay, from the lowest: compound 1; then compound 2; then compound 3.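

The aromatic position para to a large group now has its first measured single-place change: with ethyl in place of amino, this assay shows a number 0.43 log units higher from compound 2 to compound 3 (beyond the scatter). Within the data shown here, the earlier compounds offered no such pair, so this is the only step that can be read here, and it is a modest one. Nothing available explains its size. The compounds shown leave open how a longer chain, a carboxylic acid or a methoxy group would read at this same position, and whether the swap of amino for ethyl gives a similar step elsewhere on the ring.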